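Series notes: amine exchange on the thiocarbonyl carbon

The compounds below may be only part of what the source reports. "The series", "measured", "known", "first", "only" and "open" are said of these compounds alone.

Compound 3 `CN(C(=S)SCc1ccc(C(=O)Nc2ccccc2N)cc1)c1cccnc1` gives 82.5% in a functional assay on MGC-803 cells (Homo sapiens) for antiproliferative activity, read by CCK-8 assay, with a stated time of 72 h, tested at 8 uM (a higher number here means a stronger effect of the compound at the concentration tested, a lower number a weaker effect), the second highest of the three numbers. Compound 2 `Nc1ccccc1NC(=O)c1ccc(CSC(=S)N2CCN(c3ccccc3)CC2)cc1` gives 87.4%, within the scatter of compound 3, while compound 1 `Nc1ccccc1NC(=O)c1ccc(CSC(=S)N2CCN(c3ccc(Cl)cc3)CC2)cc1` gives 17.2%, far lower. Among the measured compounds shown here, the only step between measured compounds, a number 70.2 percentage points higher from compound 1 to compound 2 (beyond the scatter), concerns a substituent on an aromatic ring and does not touch the thiocarbonyl carbon. Compound 4 `CN1CCN(C(=S)SCc2ccc(C(=O)Nc3ccccc3N)cc2)CC1` differs from compound 3 by 4-methylpiperazin-1-yl in place of methyl(pyridin-3-yl)amino on a thiocarbonyl carbon. For the measured compounds named here, no measured step bears directly on this change; compounds 2 and 3 show that two different amines at this place both give high inhibition, but neither lacks an aromatic ring. A moderate downward step is expected, a number 22.5 percentage points lower from compound 3 to compound 4 (beyond the scatter), with wide uncertainty. Compound 4 is estimated at 60%, between 25% and 90%.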

Compound 4, a percentage reported as inhibition, at one concentration (the size of the read-out at that concentration, not a potency): 84.4%
For compound 4 the middle estimate is 24.4 percentage points below the measured one; the measured number falls inside the stated range.
By their numbers in this assay, from the lowest: compound 1; then compounds 3, 4 and 2 (each within the scatter of the next).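

At the thiocarbonyl carbon, a non-aromatic 4-methylpiperazin-1-yl serves as well as methyl(pyridin-3-yl)amino in this assay (a number 1.9 percentage points higher from compound 3 to compound 4 (within the scatter)), so high inhibition here does not need an aromatic ring on the amine. On the amine nitrogen in the ring, methyl matches phenyl (a number 3 percentage points lower from compound 2 to compound 4 (within the scatter)) but not 4-chlorophenyl (a number 67.2 percentage points higher from compound 1 to compound 4 (beyond the scatter)), leaving compound 1 alone among these piperazines in its low number. No evidence here explains that gap.

Open, from the compounds shown here alone, is whether an acetyl group or plain hydrogen on that ring nitrogen holds the inhibition. Also open, going by these compounds, is whether an open-chain dimethylamino group at the thiocarbonyl carbon does the same.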